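Amino Substitution on Two Purine-Type Cores in Ovarian Cells

A few compounds are considered here, and "the series" means these few. Any claim that something is new, unique, unknown or untested is made for them only; others in the source may bear on it.

The shared core carries a chloro group and a benzyl arm bearing a chloromethyl group. In compound 1 `ClCc1ccc(Cn2cnc3c(Cl)ncnc32)cc1` the arm is attached through a ring with substituents across from one another; in a functional assay on OVCAR-4 cells (Homo sapiens) for cytotoxicity, read by sulforhodamine B assay, with a stated time of 48 h (a higher number here means a weaker inhibitor of growth, a lower number a stronger inhibitor of growth), compound 1 gives 2450 nM. Compound 2 `Nc1nc(Cl)c2ncn(Cc3ccc(CCl)cc3)c2n1` differs from it by the change (amino in place of hydrogen on an aromatic carbon); in this assay compound 2 gives 15500 nM, and the step of a 6.3-fold higher number from compound 1 to compound 2 (0.80 log units; beyond the scatter) shows that this change weakened growth inhibition.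

Compound 3 `ClCc1ccccc1Cn1cnc2c(Cl)ncnc21` places the chloromethyl group differently on the benzyl arm; how its core differs from that of compound 1 is not broken down here. In this assay compound 3 gives 3380 nM, a value within the scatter of compound 1.

Compound 4 `Nc1nc(Cl)c2ncn(Cc3ccccc3CCl)c2n1` is to compound 3 what compound 2 is to compound 1: the change (amino in place of hydrogen on an aromatic carbon), at the same place, so it is the same change. Because a 6.3-fold higher number from compound 1 to compound 2 (0.80 log units; beyond the scatter) weakened inhibition, the step from compound 3 to compound 4 is expected to be of similar size, a 5.9-fold higher number from compound 3 to compound 4 (0.77 log units; beyond the scatter). Compound 4 is therefore estimated at 20000 nM, expected between 8000 nM and 50000 nM.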

Compound 4, concentration for 50% growth inhibition: 2460 nM
Estimate against measurement, compound 4: 8.1-fold (0.91 log units) above; the measured number lies below the stated range.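

In this assay, putting an amino group on the core of compound 3 gives a 1.4-fold lower number from compound 3 to compound 4 (0.14 log units; within the scatter), a step too small to tell from the usual scatter of repeated measurements. The change therefore did not carry over from one core to the other in this series, and the effect seen on one core could not be relied on for the other: the same change on two cores in this assay, a 6.3-fold higher number (0.80 log units; beyond the scatter) from compound 1 to compound 2 and a 1.4-fold lower number (0.14 log units; within the scatter) from compound 3 to compound 4, 8.7-fold (0.94 log units) apart, beyond the scatter of two such steps. This shows that the amino change can depend on its surroundings, here on where the chloromethyl group sits on the benzyl arm, but two pairs of compounds do not show why the steps differ or how the change would behave on any further core.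

From the compounds shown here alone, whether a methylamino or a hydroxyl group on the same aromatic carbon, between two ring nitrogen atoms, would behave as in compound 2 or as in compound 4 stays open. Also open, going by these compounds, is what the amino change would do with the chloromethyl group in a third place on the benzyl arm.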